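Swapping the indole of compound 2 for a benzofuran

The compounds below may be only part of what the source reports. "The series", "measured", "known", "first", "only" and "open" are said of these compounds alone.

Measured compounds and their values in a physicochemical assay for lipophilicity, at pH 7.4; on this read-out higher numbers stand for higher lipophilicity and lower numbers for lower lipophilicity:
- compound 1 `CNC(=O)c1ccc(=O)n(Cc2cc(Br)ccc2F)c1`: 2.6
- compound 2 `CNC(=O)c1cc(C(=O)NC2CC2)cn(Cc2cccc3[nH]ccc23)c1=O`: 2.9
- compound 3 `CNC(=O)c1cc(C(=O)NC2CCC2)cn(Cc2ccccn2)c1=O`: 2.2

Among these three numbers compound 2 has the top value, but the gap to compound 1 lies within the scatter, so the two cannot be ordered; only compound 3 sits beyond the scatter, below compound 2. Compound 4 `CNC(=O)c1cc(C(=O)NC2CC2)cn(Cc2cccc3occc23)c1=O` has not yet been measured in this assay. It differs from compound 2 in one place: 1-benzofuran-4-yl in place of 1H-indol-4-yl on a saturated chain carbon bound to an aromatic nitrogen. Among the measured compounds shown here, no measured pair shows this exact change. Since a hydrogen-bond donor leaves and a hydrogen-bond acceptor enters, a modest step upward is expected, roughly the size of the usual scatter or a little more, a number 0.40 log units higher from compound 2 to compound 4 (beyond the scatter). Compound 4 is therefore estimated at 3.3, within a range from 2.9 to 3.7.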

Compound 4, distribution coefficient: 3.4
Beside the measured number, compound 4's estimate is 0.10 log units below it; measured number inside the range.
By their numbers in this assay, from the lowest: compound 3; then compounds 1 and 2 (each within the scatter of the next); then compound 4.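

Among the compounds shown, this is the only pair that differs in one place, so it gives the first direct reading of this position in this assay: the change gives a number 0.50 log units higher from compound 2 to compound 4 (beyond the scatter). Under this change, the ring types and the heavy-atom count stay the same, while the hydrogen-bond donor leaves and a hydrogen-bond acceptor enters. Nothing given here accounts for the step.

Still open, as far as these compounds go, is how 1-benzothiophen-4-yl or 1-methylindol-4-yl would read at this position. From the compounds shown here alone, whether the step would hold with a cyclobutyl amide, as in compound 3, is also open.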